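The source may report more compounds than this note shows. Statements on the series, on what has been measured and on what is new or still open speak of the compounds shown alone.

Working notes on the series.

Of the compounds shown here, two have been measured in an assay on NIH3T3 cells for inhibition of Sonic hedgehog protein (Mus musculus), read by a luciferase reporter, with a stated time of 48 h; on this read-out lower numbers stand for stronger inhibition and higher numbers for weaker inhibition. Compound 1, `Cc1cccc(C)c1NC(=O)c1ccc(Nc2ncc(C3CC3)c(-c3ccc(OC(F)(F)F)cc3)n2)cc1`, gives 1.3 nM in this assay. Compound 2, `CCCc1cc(-c2ccc(OC(F)(F)F)cc2)nc(Nc2ccc(C(=O)Nc3c(C)cccc3C)cc2)n1`, gives 0.8 nM in this assay. The two numbers lie within the scatter of each other, so nothing separates compound 1 from compound 2 on the data at hand; compound 1 simply holds one of two numbers that sit close together at the strong end of the read-out.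

The next compound, compound 3, `Cc1cccc(C)c1NC(=O)c1ccc(Nc2ncc(C(F)(F)F)c(-c3ccc(OC(F)(F)F)cc3)n2)cc1`, keeps the shared core of compound 1 and changes one group: trifluoromethyl in place of cyclopropyl on an aromatic carbon. Put plainly, trifluoromethyl takes the place of cyclopropyl on an aromatic carbon. Going by the values given here, no pair of measured compounds differs only in this way, so the size of the step has no precedent; the change is small in atom count and leaves donors and acceptors unaltered.

The expectation for compound 3 is therefore a number close to that of compound 1, with a step of a 1.2-fold higher number from compound 1 to compound 3 (0.06 log units; within the scatter) not beyond the scatter. Compound 3 is estimated at 1.5 nM in this assay, with a likely range from 0.5 nM to 5 nM.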

Compound 3, half-maximal inhibitory concentration: 0.53 nM
The estimate for compound 3 lay 2.8-fold (0.45 log units) above the measured number; the measured number falls inside the stated range.
By their numbers in this assay, from the lowest: compounds 3, 2 and 1 (each within the scatter of the next, the first and the last beyond it).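

Going by these compounds alone, the step of a 2.5-fold lower number from compound 1 to compound 3 (0.39 log units; beyond the scatter) is the first measured change at this position, and it shows that in this assay the read-out responds to the group on this aromatic carbon, ortho to the 4-(trifluoromethoxy)phenyl group: with trifluoromethyl in place of cyclopropyl, inhibition is modestly stronger, a difference that lies beyond the scatter. The exchange also shows that the cyclopropyl ring is not required for a low-nanomolar number at this position, since the open trifluoromethyl group keeps the read-out at the strong end, with no hydrogen-bond donor or acceptor count changing on either side. No measurement in hand bears on the origin of this step, which rests on a single pair of compounds.

What the compounds shown leave open is how a smaller or differently built group at this position, such as a methyl group, a chlorine atom or a nitrile, would stand against cyclopropyl and trifluoromethyl, and whether an amine or a carboxylic acid would be tolerated there at all. Also open, from the compounds shown here alone, is whether the same exchange gives a step of similar size when the 4-(trifluoromethoxy)phenyl group or the dimethylphenyl amide is replaced.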